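A few compounds are considered here, and "the series" means these few. Any claim that something is new, unique, unknown or untested is made for them only; others in the source may bear on it.

Working notes on the urea series. Compound 1 `Cc1ccccc1NC(=O)N[C@@H](C)c1ccccc1` in an ADME assay on the whole organism with Oryza sativa as the target, tested at 10 uM (on this read-out lower numbers stand for a stronger effect and higher numbers for a weaker effect at the one concentration tested), gives 99%. Compound 2 `COc1ccccc1NC(=O)N[C@@H](C)c1ccccc1` gives 95%, and compound 3 `C[C@H](NC(=O)Nc1ccccc1Cl)c1ccccc1` gives 106%. Compound 1 stands second highest of the three numbers; the nearest is compound 2 and the furthest compound 3, and both steps, a number 4 percentage points lower from compound 1 to compound 2 (within the scatter) and a number 7 percentage points higher from compound 1 to compound 3 (within the scatter), lie within the scatter. For the measured compounds named here, only the step of a number 11 percentage points higher from compound 2 to compound 3 (beyond the scatter) reaches beyond it, and then modestly. Compound 4 `Cc1cc(F)ccc1NC(=O)N[C@@H](C)c1ccccc1` differs from compound 1 by fluoro in place of hydrogen on an aromatic carbon. Going by the values given here, none of the measured steps replaces hydrogen with fluoro; all three exchange one group on an aromatic carbon for another, and all stay small, so the series gives no example of a change that moves this read-out far. On that basis no step beyond the scatter is expected from compound 1 to compound 4, the expected step being a number 1 percentage points higher from compound 1 to compound 4 (within the scatter). Compound 4 is therefore estimated at 100%, with a range from 88% to 112%.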

Compound 4, a percentage reported as activity, at one concentration (the size of the read-out at that concentration, not a potency): 96%
Beside the measured number, compound 4's estimate is 4 percentage points above it; low and high end bracket the measured number.
By their numbers in this assay, from the lowest: compounds 2, 4, 1 and 3 (each within the scatter of the next, the first and the last beyond it).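

In this assay, fluoro in place of hydrogen, para to a large group and meta to a methyl group, gives a number 3 percentage points lower from compound 1 to compound 4 (within the scatter). The earlier steps shown here exchanged one group for another on an aromatic carbon, whereas this one adds a group at a carbon that carries only hydrogen in compound 1, and at this position a single fluorine atom does not move the read-out beyond the scatter. The data offer no explanation for the size of this step.

From the compounds shown here alone, whether an amine or a carboxylic acid at this same carbon would produce a step beyond the scatter remains open. Also open, going by these compounds, is whether fluoro at this position gives a similar step on the core of compound 2 or compound 3.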